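A few compounds are considered here, and "the series" means these few. Any claim that something is new, unique, unknown or untested is made for them only; others in the source may bear on it.

Measured so far:
- compound 1 `O=[N+]([O-])c1cc(CSc2nnnn2Cc2ccccc2)cc([N+](=O)[O-])c1`: > 30000 nM
- compound 2 `O=[N+]([O-])c1cc(CSc2nnnn2C2CCCCC2)cc([N+](=O)[O-])c1`: > 30000 nM
- compound 3 `O=[N+]([O-])c1cc(C[Se]c2nnnn2Cc2ccccc2)cc([N+](=O)[O-])c1`: > 30000 nM

In an ADME assay on HeLa cells (Homo sapiens) for cytotoxicity, read by MTT assay, with a stated time of 48 h (on this read-out lower numbers stand for stronger inhibition and higher numbers for weaker inhibition), each of these three values is a limit of the assay and not a number, as the limit of > 30000 nM in this assay, at which 3 of the 3 values shown sit, records. Compound 1 and compound 2 differ by cyclohexyl in place of benzyl on an aromatic nitrogen, and the step that the two limits leave unreadable from compound 1 to compound 2 cannot be read from two limits. The difference between the cores of compound 1 and compound 3 is not broken down here. Compound 4 `O=[N+]([O-])c1cc(C[Se]c2nnnn2C2CCCCC2)cc([N+](=O)[O-])c1`, still to be measured in this assay, carries the same change on the core of compound 3: cyclohexyl in place of benzyl on an aromatic nitrogen. Because the limit of > 30000 nM in this assay, at which 3 of the 3 values shown sit, holds for every value shown, he expects the step that the limit leaves unreadable from compound 3 to compound 4 to leave compound 4 at the same limit. His estimate for compound 4 is therefore 40000 nM, spanning 20000 nM to 100000 nM.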

Compound 4, half-maximal inhibitory concentration: > 30000 nM
Compound 4 was reported as a limit (the forecaster's own chance of this, stated with the estimate: 85%); the middle value lies beyond the limit too.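

No step can be read from compound 3 to compound 4, because both values are limits of the assay and not numbers: the limit of > 30000 nM in this assay, at which 4 of the 4 values shown sit. The compounds shown leave open how cyclohexyl and benzyl compare on either core.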